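From fluoro to trifluoromethyl on a shared core

The source may hold more compounds than are shown below. What is called first, only, known or untested is meant among the compounds shown, and "the series" means these compounds.

Three compounds sharing one core have numbers in a functional assay on HepG2 cells (Homo sapiens) for antiproliferative activity, read by MTT assay, with a stated time of 24 h; on this read-out higher numbers stand for weaker inhibition and lower numbers for stronger inhibition: compound 1 (`O=[N+]([O-])c1ccc(S(=O)(=O)n2c(-c3cn(-c4ccccc4)nc3-c3ccc(F)cc3)nc3ccccc32)cc1`), compound 2 (`O=S(=O)(c1ccc(Br)cc1)n1c(-c2cn(-c3ccccc3)nc2-c2ccc(F)cc2)nc2ccccc21`) and compound 3 (`O=S(=O)(c1ccc(C(F)(F)F)cc1)n1c(-c2cn(-c3ccccc3)nc2-c2ccc(F)cc2)nc2ccccc21`). In this assay compound 1 gives 1340 nM, compound 2 gives 2550 nM and compound 3 gives 1680 nM. Compound 2 therefore stands within the scatter of both of the others. The measurements show a 1.9-fold higher number from compound 1 to compound 2 (0.28 log units; within the scatter) and a 1.5-fold lower number from compound 2 to compound 3 (0.18 log units; within the scatter).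

The account now turns to compound 4 (`O=S(=O)(c1ccc(Br)cc1)n1c(-c2cn(-c3ccccc3)nc2-c2ccc(C(F)(F)F)cc2)nc2ccccc21`), whose difference from compound 2 is trifluoromethyl in place of fluoro on an aromatic carbon. This is trifluoromethyl in place of fluoro on an aromatic carbon, turning 4-fluorophenyl into 4-(trifluoromethyl)phenyl. Within the data shown here, no measured step touches this place, so the evidence is only indirect. Trifluoromethyl enters at another place in two measured steps, a 1.3-fold higher number from compound 1 to compound 3 (0.10 log units; within the scatter) and a 1.5-fold lower number from compound 2 to compound 3 (0.18 log units; within the scatter), and both stay within the scatter. Those steps give no ground for expecting a real shift in either direction, though the data cannot rule one out at the new place. The expected change is a 1.1-fold lower number from compound 2 to compound 4 (0.03 log units; within the scatter), a step not beyond the scatter. For compound 4 the estimated value is 2400 nM, with an expected range of 1100 nM to 5200 nM.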

Compound 4, half-maximal inhibitory concentration: 2160 nM
Estimate against measurement, compound 4: 1.1-fold (0.05 log units) above; the range from low to high includes it.
By their numbers in this assay, from the lowest: compounds 1, 3, 4 and 2 (each within the scatter of the next).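

Among these compounds, compound 4 gives the first direct reading at this place, the 4-fluorophenyl group that all the earlier compounds share: in this assay, the change to 4-(trifluoromethyl)phenyl gives a 1.2-fold lower number from compound 2 to compound 4 (0.07 log units; within the scatter). With the bromo group held constant, replacing fluoro, a single heavy atom, with trifluoromethyl, four heavy atoms, on this aromatic carbon therefore produces no step beyond the scatter, so trifluoromethyl has now stayed within the scatter in every listed step that introduces it, at both places. No other measurement bears on this result, so the data offer no account of it.

The compounds shown leave open whether an amine, a carboxylic acid or a longer chain such as n-butyl at this place, on an aromatic carbon of the six-membered ring, would also stay within the scatter, since fluoro and trifluoromethyl are the only groups seen here. From the compounds shown here alone, it also remains open whether the change from fluoro to trifluoromethyl would read the same with nitro or trifluoromethyl in place of the bromo group of compound 4.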